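Aryl change on the shared core: chlorines out, hydroxyl in

The source may report more compounds than this note shows. Statements on the series, on what has been measured and on what is new or still open speak of the compounds shown alone.

Three compounds of the series carry a measurement in a functional assay (muscle tissue) with Cavia porcellus as the target; on this read-out lower numbers stand for an effect already at smaller amounts and higher numbers for an effect only at larger amounts of compound. Compound 1 `COC(=O)C1=C(C)N=C(C)/C(=C(\O)OC)C1c1cc(Cl)cc(Cl)c1` gives 93.3 nM in this assay and stands second highest of the three numbers. Its nearest neighbour is compound 3 `COC(=O)C1=C(C)N=C(C)/C(=C(/O)OC)C1c1cccc(Cl)c1`, which gives 15.9 nM in this assay, a lower number by a gap beyond the scatter. Furthest away is compound 2 `COC(=O)C1=C(C)N=C(C)/C(=C(\O)OC)C1c1cc(OC)c(OC)cc1OC`, which gives 1000000 nM in this assay, far above both others. Going by the values given here, no two measured compounds differ in one place only, so no single-point step is known.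

Compound 4 `COC(=O)C1=C(C)N=C(C)/C(=C(\O)OC)C1c1cccc(O)c1` is not yet measured. It differs from compound 1 as follows: 3-hydroxyphenyl in place of 3,5-dichlorophenyl on a saturated ring carbon. Nothing measured connects these two aryl groups directly, and the spread among compounds 1, 2 and 3 shows how strongly the aryl group moves the number in this assay. The move is expected to raise the number beyond the scatter, an 11-fold higher number from compound 1 to compound 4 (1.03 log units; beyond the scatter). Compound 4 is estimated at 1000 nM in this assay, with a range from 150 nM to 8000 nM.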

Compound 4, half-maximal effective concentration: 1000 nM
For compound 4 middle estimate and measured number coincide at the digits printed, and the stated range covers the measured number.
By their numbers in this assay, from the lowest: compound 3; then compound 1; then compound 4; then compound 2.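

In this assay, going by these compounds alone, the exchange of 3,5-dichlorophenyl for 3-hydroxyphenyl on the saturated ring carbon gives the first single-place step, an 11-fold higher number from compound 1 to compound 4 (1.03 log units; beyond the scatter). Within the data shown here, the spread among the earlier compounds came with other differences between them, whereas this step shows directly, with the rest of the structure held constant, that the number responds to the aryl group at this position. Nothing at hand bears on why the number moves with this change.

The step removes both chlorines and brings in the hydroxyl together, so the compounds shown do not separate what each of these contributes. Also open, as far as these compounds go, is how an amine or a carboxylic acid in place of the hydroxyl on this phenyl group would read in this assay.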